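From benzyl to 2-phenoxyethyl on the amide nitrogen

This account rests on a few compounds, and the source may have more. Where it says the series, first, only, none or still open, it means among the compounds named here.

In a functional assay on HeLa cells (Homo sapiens) for cytotoxicity, read by resazurin assay, with a stated time of 72 h (a lower number here means a stronger inhibitor, a higher number a weaker inhibitor), compound 3 (`CCSC(=S)SCC(=O)c1ccc(C(=O)NCc2ccccc2)cc1`) reads 23900 nM and sits level with compound 2 (`CCSC(=S)SCC(=O)c1ccc(C(=O)Nc2ccccc2)cc1`) at 25800 nM while compound 1 (`COc1ccc(C(=O)CSC(=S)SCCOc2ccccc2)cc1`) at 5460 nM lies lower by more than the scatter. Compound 4 (`CCSC(=S)SCC(=O)c1ccc(C(=O)NCCOc2ccccc2)cc1`) differs from compound 3 by phenoxymethyl in place of phenyl on a saturated chain carbon bound to an amide-type nitrogen; cut one bond further out, this reads benzyl to 2-phenoxyethyl. Among the compounds with values here, the only measured step on this nitrogen is benzyl in place of phenyl (a 1.1-fold lower number from compound 2 to compound 3 (0.03 log units; within the scatter)), which gives little reason to expect a large move. Compound 1 does carry a 2-phenoxyethyl group, though at another place in its structure, and its 5460 nM tilts the expectation slightly toward a lower number. In this assay the expected change is a 1.7-fold lower number from compound 3 to compound 4 (0.23 log units; within the scatter) and so remains within the scatter. For compound 4 the estimated value is 14000 nM with 5500 nM to 30000 nM as the expected range.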

Compound 4, half-maximal inhibitory concentration: 18200 nM
Estimate against measurement, compound 4: 1.3-fold (0.11 log units) below; the measured number falls inside the stated range.
By their numbers in this assay, from the lowest: compound 1; then compounds 4, 3 and 2 (each within the scatter of the next).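

In this assay, the amide nitrogen has now carried phenyl, benzyl and 2-phenoxyethyl, and the readings stay together. Phenoxymethyl in place of phenyl on a saturated chain carbon bound to an amide-type nitrogen gives a 1.3-fold lower number from compound 3 to compound 4 (0.12 log units; within the scatter), and going straight from the phenyl amide to the 2-phenoxyethyl amide gives a 1.4-fold lower number from compound 2 to compound 4 (0.15 log units; within the scatter). Introducing the phenoxymethyl oxygen and its hydrogen-bond acceptor therefore moves the number no further than the scatter in these compounds, and no measurement given here accounts for the three groups reading alike.

As far as these compounds go, whether this position stays as flat with a group of another kind, such as an amine or a carboxylic acid at the end of the chain, remains open. Compound 1 differs from these compounds in more than one place, so it cannot show what the 2-phenoxyethyl group contributes on its own.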